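The source may hold more compounds than are shown below. What is called first, only, known or untested is meant among the compounds shown, and "the series" means these compounds.

Measured in a functional assay on RAW264.7 cells (Mus musculus) for inhibition, with stated times of 1 h and 24 h; on this read-out lower numbers stand for stronger inhibition and higher numbers for weaker inhibition:
Compound 1 `CCCS(=O)(=O)Oc1ccc2c3c(c(=O)oc2c1)CCCCCC3`: 4.02 nM
Compound 2 `Cc1ccc(S(=O)(=O)Oc2ccc3c4c(c(=O)oc3c2)CCCCCC4)cc1`: 6.75 nM

Compound 2, at 6.75 nM, stands within the scatter of compound 1, so the two numbers cannot be told apart. The next compound is compound 3 `O=c1oc2cc(OS(=O)(=O)c3ccc(C(F)(F)F)cc3)ccc2c2c1CCCCCC2`, which differs from compound 2 by one change: trifluoromethyl in place of methyl on an aromatic carbon. In words, this is trifluoromethyl in place of methyl on an aromatic carbon, para to a large group. Within the data shown here, the only measured step, a 1.7-fold higher number from compound 1 to compound 2 (0.23 log units; within the scatter), came with 4-methylphenyl in place of propyl on a sulfonyl sulfur, and it lies within the scatter. No measurement covers the methyl to trifluoromethyl change itself, so this step is only a loose guide. On that basis, no change beyond the scatter is expected in this assay. The expected step is a 1.0-fold lower number from compound 2 to compound 3 (0.02 log units; within the scatter). For compound 3 the estimated value is 6.5 nM, with an expected range of 2.5 nM to 17 nM.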

Compound 3, half-maximal inhibitory concentration: 6.04 nM
Beside the measured number, compound 3's estimate is 1.1-fold (0.03 log units) above it, and the stated range covers the measured number.
By their numbers in this assay, from the lowest: compounds 1, 3 and 2 (each within the scatter of the next).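

In this assay, trifluoromethyl in place of methyl on an aromatic carbon, para to a large group, gives a 1.1-fold lower number from compound 2 to compound 3 (0.05 log units; within the scatter) and so brings no change that can be told from the scatter, although four heavy atoms enter where one leaves. The sulfonyl sulfur tells the same story: with 4-(trifluoromethyl)phenyl in place of propyl, the result is a 1.5-fold higher number from compound 1 to compound 3 (0.18 log units; within the scatter) and compound 3 cannot be separated from compound 1. Nothing available explains why these numbers stay so close.

The compounds shown leave open whether an amine or a carboxylic acid on that aromatic carbon would also leave the number in place. They also leave open how a longer chain than propyl on the sulfonyl sulfur would read.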